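Dropping the Methyl on the Triazole Aryl Ring

This account rests on a few compounds, and the source may have more. Where it says the series, first, only, none or still open, it means among the compounds named here.

Measured compounds:
- compound 1, `C=C1C[C@]23C[C@@]1(O)CC[C@H]2c1ccc(OS(=O)(=O)c2ccc(C)cc2)c(C)c1[C@@H]3Cn1cc(-c2ccc(OC)cc2)nn1`: in a functional assay on MCF7 cells (Homo sapiens) for cytotoxicity, read by MTT assay, with a stated time of 4 days (on this read-out lower numbers stand for stronger inhibition and higher numbers for weaker inhibition), compound 1 gives > 20000 nM, which is a limit of the assay, not a number (the limit of > 20000 nM in this assay, at which 1 of the 3 values shown sits).
- compound 2, `C=C1C(=O)[C@]23C[C@@]1(O)CC[C@H]2c1ccc(O)c(C)c1[C@@H]3Cn1cc(-c2ccc(C)cc2)nn1`: compound 2 gives 370 nM.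
- compound 3, `C=C1C(=O)[C@]23C[C@@]1(O)CC[C@H]2c1ccc(OS(=O)(=O)c2ccc(C)cc2)c(C)c1[C@@H]3Cn1cc(-c2ccc(C)cc2)nn1`: compound 3 gives 320 nM.

Compound 2 stands highest of the two numbers, with compound 3 nearest, a 1.2-fold lower number from compound 2 to compound 3 (0.06 log units; within the scatter), a step within the scatter. Compound 4, `C=C1C(=O)[C@]23C[C@@]1(O)CC[C@H]2c1ccc(O)c(C)c1[C@@H]3Cn1cc(-c2ccccc2)nn1`, differs from compound 2 by hydrogen in place of methyl on an aromatic carbon. Going by the values given here, the only measured step, a 1.2-fold lower number from compound 2 to compound 3 (0.06 log units; within the scatter), concerns a different place and does not bear on this change. Among the compounds with values here, with no step on this position to draw on, compound 4 is expected to sit close to compound 2, a step of a 1.2-fold higher number from compound 2 to compound 4 (0.09 log units; within the scatter) that stays within the scatter. Compound 4 is therefore estimated at 450 nM, between 150 nM and 1400 nM.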

Compound 4, half-maximal inhibitory concentration: 1740 nM
Estimate against measurement, compound 4: 3.9-fold (0.59 log units) below, outside the stated range (above it).
By their numbers in this assay, from the lowest: compounds 3 and 2 (each within the scatter of the next); then compound 4. At a limit, above all of these: compound 1.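

In this assay, replacing 4-methylphenyl with phenyl gives a 4.7-fold higher number from compound 2 to compound 4 (0.67 log units; beyond the scatter). This is the first step among the compounds shown that lies beyond the scatter, so the methyl on this aromatic carbon, para to a large group, cannot be exchanged for hydrogen without a measurable change in this read-out. No available evidence bears on the reason for this difference.

Going by these compounds, what an amine, a carboxylic acid or a longer chain such as ethyl would give on this carbon stays open. On these data alone, whether the effect of this methyl holds with a different group on the ring oxygen also remains open.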